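Amide Aryl Swaps on a Shared Core

The source may report more compounds than this note shows. Statements on the series, on what has been measured and on what is new or still open speak of the compounds shown alone.

Compound 1 `O=C(Nc1cccc(-c2oc3cc(-c4ccc(F)cc4)ccc3c(=O)c2O)c1)c1ccc(Cl)cc1` gives 11000 nM in a functional assay on HepG2 cells (Homo sapiens) for antiproliferative activity, read by CCK-8 assay, with a stated time of 72 h; on this read-out higher numbers stand for weaker inhibition and lower numbers for stronger inhibition.
Compound 2 `COc1ccccc1C(=O)Nc1cccc(-c2oc3cc(-c4ccc(F)cc4)ccc3c(=O)c2O)c1` gives 14500 nM in this assay.
Compound 3 `Cc1cc(C(=O)Nc2cccc(-c3oc4cc(-c5ccc(F)cc5)ccc4c(=O)c3O)c2)ccc1F` gives 9540 nM in this assay.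

Compound 3 holds the lowest of the three numbers, yet the steps of a 1.2-fold lower number from compound 1 to compound 3 (0.06 log units; within the scatter) and a 1.5-fold lower number from compound 2 to compound 3 (0.18 log units; within the scatter) both stay within the scatter, so the three compounds cannot be told apart. Compound 4 `Cc1cc(C)cc(C(=O)Nc2cccc(-c3oc4cc(-c5ccc(F)cc5)ccc4c(=O)c3O)c2)c1` differs from compound 3 by 3,5-dimethylphenyl in place of 4-fluoro-3-methylphenyl on a carbonyl carbon. Every measured step changes the aryl group on that same carbonyl carbon: a 1.3-fold higher number from compound 1 to compound 2 (0.12 log units; within the scatter), a 1.2-fold lower number from compound 1 to compound 3 (0.06 log units; within the scatter) and a 1.5-fold lower number from compound 2 to compound 3 (0.18 log units; within the scatter), none beyond the scatter. The change to compound 4 is therefore expected to bring no step beyond the scatter, a 1.0-fold higher number from compound 3 to compound 4 (0.02 log units; within the scatter). Compound 4 is estimated at 10000 nM in this assay, within a range from 5000 nM to 22000 nM.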

Compound 4, half-maximal inhibitory concentration: 13400 nM
For compound 4 the middle estimate is 1.3-fold (0.13 log units) below the measured one, and the stated range covers the measured number.
By their numbers in this assay, from the lowest: compounds 3, 1, 4 and 2 (each within the scatter of the next).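

With 3,5-dimethylphenyl, an aryl group of carbon only, on the carbonyl carbon, the steps in this assay all stay within the scatter: a 1.4-fold higher number from compound 3 to compound 4 (0.15 log units; within the scatter) and a 1.1-fold lower number from compound 2 to compound 4 (0.03 log units; within the scatter) and a 1.2-fold higher number from compound 1 to compound 4 (0.09 log units; within the scatter). The numbers at this position therefore hold at the same level without the fluorine of compound 3, the chlorine of compound 1 or the methoxy of compound 2. No measurement here explains these steps.

From the compounds shown here alone, whether an amine or a carboxylic acid on this aryl ring, or a cyclohexyl group in its place, would move the number beyond the scatter stays open. The compounds shown also leave open how far changes elsewhere on the shared core matter.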